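Swapping the Amine Tail: Cytotoxicity of a Second Pair

This account rests on a few compounds, and the source may have more. Where it says the series, first, only, none or still open, it means among the compounds named here.

Compound 1 `CN1CCN(CCCNCc2cn(-c3ccc(C(F)(F)F)cc3)nc2-c2ccc(Cl)cc2)CC1`: 2500 nM
Compound 2 `CCCN1CCC(CNCc2cn(-c3ccc(F)cc3F)nc2-c2ccccc2C)CC1`: > 20000 nM, a limit of the assay rather than a number
Compound 3 `CCCN1CCC(CNCc2cn(-c3ccc(C(F)(F)F)cc3)nc2-c2ccc(Cl)cc2)CC1`: 1900 nM

All three were tested in an ADME assay on Huh-7 cells (Homo sapiens) for cytotoxicity; on this read-out lower numbers stand for higher toxicity in this test and higher numbers for lower toxicity in this test. Compound 3 and compound 1 share one core and differ in a single place: 2-(4-methylpiperazin-1-yl)ethyl in place of 1-propylpiperidin-4-yl on a saturated chain carbon bound to an amine nitrogen. That step reads a 1.3-fold higher number from compound 3 to compound 1 (0.12 log units; within the scatter). Compound 2 gives only a limit in this assay, so no number stands for it. How the core of compound 2 differs from the core of compound 3 is not broken down here.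

Compound 4 `Cc1ccccc1-c1nn(-c2ccc(F)cc2F)cc1CNCCCN1CCN(C)CC1` has not yet been measured in this assay. It stands to compound 2 exactly as compound 1 stands to compound 3, the same change at the same place: 2-(4-methylpiperazin-1-yl)ethyl in place of 1-propylpiperidin-4-yl on a saturated chain carbon bound to an amine nitrogen. The expectation for compound 4 rests on compound 2 sitting at the limit of > 20000 nM in this assay, at which 1 of the 3 values shown sits, and on the matching step having read a 1.3-fold higher number from compound 3 to compound 1 (0.12 log units; within the scatter). Compound 4 is therefore estimated to lie around 25000 nM, most likely between 12000 nM and 60000 nM. The step this estimate implies, a step that the limit leaves unreadable from compound 2 to compound 4, is expected to be small, and the assay may well again report only a limit.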

Compound 4, half-maximal cytotoxic concentration: > 20000 nM
Compound 4: a limit, no number; the forecaster's own chance of this, stated with the estimate: 60%; the middle value lies beyond the limit too.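

In this assay compound 2 and compound 4 both give a limit of the assay rather than a number, so the step between them cannot be read. The compounds shown leave open whether 2-(4-methylpiperazin-1-yl)ethyl in place of 1-propylpiperidin-4-yl changes the read-out at all on the core of compound 2.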